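The source may report more compounds than this note shows. Statements on the series, on what has been measured and on what is new or still open speak of the compounds shown alone.

Measured compounds in a functional assay on HEK293 cells for agonist activity at probable G-protein coupled receptor 27 (Homo sapiens), read by a luciferase reporter and beta-arrestin recruitment, with a stated time of 10 min; on this read-out lower numbers stand for an effect already at smaller amounts and higher numbers for an effect only at larger amounts of compound:
- compound 1, `Cc1cc(Br)ccc1C(=O)Nc1ccc(S(=O)(=O)Nc2ccccc2)cc1`, 851 nM
- compound 2, `COc1cc(Br)ccc1C(=O)Nc1ccc(S(=O)(=O)Nc2ccccc2)cc1`, 1020 nM

Compound 2 stands next to compound 1 on these numbers: a 1.2-fold higher number from compound 1 to compound 2 (0.08 log units; within the scatter), a difference within the scatter, so the two cannot be told apart. Within the data shown here, the only step measured so far is this one, methoxy in place of methyl on an aromatic carbon, and it changed nothing beyond the scatter.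

Compound 3, `O=C(Nc1ccc(S(=O)(=O)Nc2ccccc2)cc1)c1ccc(I)cc1F`, is the unmeasured compound. Compared with compound 2 it carries 2-fluoro-4-iodophenyl in place of 4-bromo-2-methoxyphenyl on a carbonyl carbon. Among the measured compounds shown here, the single measured step touches the same ring but exchanges one small group for another, whereas here the whole group on the carbonyl carbon is replaced, halogen included. Nothing in the data shows how such a replacement moves this assay, so it is expected that compound 3 stays near compound 2, with a wide range: a 1.0-fold lower number from compound 2 to compound 3 (0.01 log units; within the scatter), giving an estimate of 1000 nM for compound 3, between 300 nM and 3500 nM.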

Compound 3, half-maximal effective concentration: 5130 nM
Compound 3: the middle estimate sits 5.1-fold (0.71 log units) below what was measured, and the stated range ends below it.
By their numbers in this assay, from the lowest: compounds 1 and 2 (each within the scatter of the next); then compound 3.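

Replacing the whole group on the carbonyl carbon moved this assay beyond the scatter, with a 5.0-fold higher number from compound 2 to compound 3 (0.70 log units; beyond the scatter) and with a 6.0-fold higher number from compound 1 to compound 3 (0.78 log units; beyond the scatter) as well, whereas methoxy in place of methyl had given only a 1.2-fold higher number from compound 1 to compound 2 (0.08 log units; within the scatter) and no difference that could be read. This place in the series therefore does respond to what it carries, and 2-fluoro-4-iodophenyl needs larger amounts of compound for its effect than either of the two bromine-bearing groups. Nothing available explains this shift.

The compounds shown leave open whether the iodine or the fluorine carries the change, as the two enter together and both earlier groups leave at once. As far as these compounds go, how an amine or a carboxylic acid on this ring would read in this assay also stays open.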